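Taking away the second bromo group: what to expect

A few compounds are considered here, and "the series" means these few. Any claim that something is new, unique, unknown or untested is made for them only; others in the source may bear on it.

Three compounds have been measured in a functional assay on the whole organism with Mus musculus as the target, in the writhing test, at a dose of 100 mg/kg by the intraperitoneal route; a higher number here means more inhibition at the dose given (going by the name of the read-out), a lower number less inhibition:

Compound 1, `Brc1ccc(OCCOc2nc3ccccc3s2)c(Br)c1`, gives 68.6%.
Compound 2, `Brc1ccc(OCCOc2nc3ccccc3s2)cc1`, gives 68.6%.
Compound 3, `COc1cc(COc2nc3ccccc3s2)cc(OC)c1`, gives 51.9%.

Compound 2 stands level with compound 1 at the digits printed, and together they are the highest of the three numbers; compound 3 lies lower, beyond the scatter. Within the data shown here, the one step between measured compounds that differ in a single place runs from compound 1 to compound 2 and amounts to no change at the digits printed from compound 1 to compound 2 (within the scatter), a change of hydrogen in place of bromo on an aromatic carbon.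

The next compound, compound 4, `c1ccc(OCCOc2nc3ccccc3s2)cc1`, is not yet measured. It differs from compound 2 by hydrogen in place of bromo on an aromatic carbon. Among the measured compounds shown here, the only step that bears on this change is the one from compound 1 to compound 2, where the same kind of swap left the read-out unchanged within the scatter. A step of similar size, that is none beyond the scatter, is therefore expected here, though a bromo group in a different place is being removed, so the range is kept wide. The expected step from compound 2 to compound 4 is a number 6.6 percentage points lower from compound 2 to compound 4 (within the scatter). For compound 4 the estimate is 62%, with a range from 45% to 78%.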

Compound 4, a percentage reported as inhibition, in the whole organism at one dose (the size of the read-out at that dose, not a potency): "not active" (no number reported)
Compound 4 has no reported number here; no gap can be computed for the estimate.
By their numbers in this assay, from the lowest: compound 3; then compounds 1 and 2 (each within the scatter of the next).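

In this assay, among these compounds, compound 4 is reported as "not active" (no number reported), with no number, so no step from compound 2 to compound 4 can be read. The compounds shown leave open how far inhibition at this dose falls, if at all, when the bromo group of compound 2 gives way to hydrogen. No measurement here explains this result.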